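Working notes: from compound 3 to compound 4

This account rests on a few compounds, and the source may have more. Where it says the series, first, only, none or still open, it means among the compounds named here.

Measured compounds:
- compound 1 `CNC(=S)NCCC(O)c1cc(OC)ccc1N`: in an assay for inhibition of Nitric oxide synthase, inducible (Homo sapiens), read by ELISA, with a stated time of 30 min (a higher number here means a weaker inhibitor, a lower number a stronger inhibitor), compound 1 gives 180000 nM
- compound 2 `COc1ccc(N)c(C(O)CCNC(=N)c2ccccc2)c1`: in this assay compound 2 gives 22500 nM
- compound 3 `CC(=N)NCCC(=O)c1ccccc1N`: in this assay compound 3 gives > 1000000 nM

Compound 3 stands at the edge of what this assay reports: its value > 1000000 nM is a limit of the assay, not a number (the limit of > 1000000 nM in this assay, at which 1 of the 3 values shown sits). Compound 2 and compound 1, both of which carry methoxy and amino groups on the ring, return numbers rather than limits in this assay, though each of them differs from compound 3 in more than one place, so no single step can be read from them.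

Compound 4 `COc1ccc(N)c(C(=O)CCNC(C)=N)c1` differs from compound 3 in one place: methoxy in place of hydrogen on an aromatic carbon. Among the measured compounds shown here, no measured pair differs only in this way, so the size of the step in this assay is open. The numbers of compound 2 and compound 1 show that compounds bearing methoxy can be measured in this assay, but neither is a clean comparison. The expectation is a small move toward stronger inhibition, near the scatter; the step from compound 3 to compound 4 is estimated as an at least 1.4-fold lower number from compound 3 to compound 4 (0.15 log units; that floor lies within the scatter). Compound 4 is estimated at 700000 nM, between 150000 nM and 3000000 nM, with a real chance that this assay again reports only a limit.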

Compound 4, half-maximal inhibitory concentration: 59700 nM
For compound 4 the middle estimate is 12-fold (1.07 log units) above the measured one, and the stated range ends above it.
By their numbers in this assay, from the lowest: compound 2; then compound 4; then compound 1. At a limit, above all of these: compound 3.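

In this assay, methoxy in place of hydrogen on an aromatic carbon, para to an amino group, gives an at least 16-fold lower number from compound 3 to compound 4 (1.22 log units; beyond the scatter). Among the compounds shown here, this is the first change that can be read in one place, and it shows that this ring position is not silent: with methoxy there, compound 4 returns a number, 59700 nM, in the same assay. The value of compound 3 is a limit and not a number, so the step gives only a floor, and its full size remains unknown: the limit of > 1000000 nM in this assay, at which 1 of the 4 values shown sits.

Whether this step belongs to methoxy itself or would also follow from another group on the same carbon stays open, as a hydroxyl group, a chlorine atom or an ethoxy group at this position is not among the compounds shown. As far as these compounds go, compound 1 and compound 2 each differ from compound 4 in more than one place, so steps to them cannot be read, and whether methoxy has a similar effect with the other side chains also remains open.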